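Positional swap of trifluoromethyl on the sulfur-linked aryl

The source may report more compounds than this note shows. Statements on the series, on what has been measured and on what is new or still open speak of the compounds shown alone.

Compound 1 `CC(O)(CSc1cccc(C(F)(F)F)c1)C(=O)Nc1cccc(S(F)(F)(F)(F)F)c1` and compound 2 `CC(O)(CSc1ccccc1C(F)(F)F)C(=O)Nc1cccc(S(F)(F)(F)(F)F)c1` share a core built on a sulfur bearing a saturated chain carbon; in a functional assay on LNCaP cells (Homo sapiens) for antiproliferative activity, read by propidium iodide staining, with a stated time of 96 h (on this read-out higher numbers stand for weaker inhibition and lower numbers for stronger inhibition), compound 1 gives 12700 nM and compound 2 gives 12300 nM. The change between them, (2-(trifluoromethyl)phenyl in place of 3-(trifluoromethyl)phenyl on a sulfur), produced a 1.0-fold lower number from compound 1 to compound 2 (0.01 log units; within the scatter).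

Compound 3 `CC(O)(CS(=O)(=O)c1cccc(C(F)(F)F)c1)C(=O)Nc1ccc(S(F)(F)(F)(F)F)cc1` is built on a different core, the sulfur here being a sulfonyl sulfur; the difference between the two cores is not broken down here. In this assay compound 3 gives 21000 nM, and its gaps to compound 1 and to compound 2 stay within the scatter, so no order among the three is claimed.

Compound 4 `CC(O)(CS(=O)(=O)c1ccccc1C(F)(F)F)C(=O)Nc1ccc(S(F)(F)(F)(F)F)cc1` carries the same kind of change as compound 2, (2-(trifluoromethyl)phenyl in place of 3-(trifluoromethyl)phenyl on a sulfonyl sulfur). The place is not the same word for word: in compound 2 the group sits on a sulfur whose other neighbours are a saturated chain carbon, in compound 4 on a sulfonyl sulfur whose other neighbours are a saturated chain carbon. Going by the values given here, since the only measured instance of this kind of change, from compound 1 to compound 2, gave a 1.0-fold lower number from compound 1 to compound 2 (0.01 log units; within the scatter), the step is expected to stay within the scatter, a 1.1-fold lower number from compound 3 to compound 4 (0.02 log units; within the scatter). Compound 4 is therefore estimated at 20000 nM in this assay, with a range from 10000 nM to 42000 nM.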

Compound 4, half-maximal inhibitory concentration: 10800 nM
The estimate for compound 4 lay 1.9-fold (0.27 log units) above the measured number; the range from low to high includes it.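

In this assay the swap gives a 1.9-fold lower number from compound 3 to compound 4 (0.29 log units; within the scatter), so on the sulfonyl core, as on the sulfur core, the number does not move beyond the scatter. Set side by side, the two steps do not differ: the same change on two cores in this assay, a 1.0-fold lower number (0.01 log units; within the scatter) from compound 1 to compound 2 and a 1.9-fold lower number (0.29 log units; within the scatter) from compound 3 to compound 4, 1.9-fold (0.27 log units) apart, within the scatter of two such steps. Going by these compounds alone, this shows that 2-(trifluoromethyl)phenyl in place of 3-(trifluoromethyl)phenyl behaves alike on these two cores in this assay, with no readable change on either; it does not show a gain or a loss from the swap on either core, and with only two pairs it says nothing about a core where the swap might move the number.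

Still open, on these data alone, is whether another group in place of trifluoromethyl on the aryl ring, such as a nitrile, a methoxy group, an amine or a carboxylic acid, would take the number beyond the scatter in this assay. Also open, as far as these compounds go, is how the sulfur and the sulfonyl sulfur compare on their own, as the cores of compound 1 and compound 3 differ in more than that one place.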